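A few compounds are considered here, and "the series" means these few. Any claim that something is new, unique, unknown or untested is made for them only; others in the source may bear on it.

Two members of the series are measured so far. Compound 1 `O=C1Nc2ccc(Cl)cc2/C1=C/c1cccc(OCc2cn(Cc3ccccc3)nn2)c1` is one of them; in a functional assay on PC-3 cells (Homo sapiens) for inhibition, read by MTT assay, with a stated time of 48 h (a higher number here means a weaker inhibitor, a lower number a stronger inhibitor), compound 1 gives only a limit, > 50000 nM. Compound 2 `O=C1Nc2ccc(Br)cc2/C1=C/c1cccc(OCc2cn(Cc3ccccc3)nn2)c1` carries bromo in place of chloro on an aromatic carbon; in this assay compound 2 likewise gives only a limit, > 50000 nM. The step that the two limits leave unreadable from compound 1 to compound 2 therefore has no readable size, since both measured values sit at the limit of > 50000 nM in this assay, at which 2 of the 2 values shown sit. On the numbers shown, compound 2 stands at a limit, not at a number, and the one further value in the series is a limit as well.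

Compound 3 `CC(=O)c1ccc2c(c1)/C(=C/c1cccc(OCc3cn(Cc4ccccc4)nn3)c1)C(=O)N2` is not yet measured. It differs from compound 2 by acetyl in place of bromo on an aromatic carbon. Among the measured compounds shown here, the only measured step that bears on this change is the one from chloro to bromo, and that step is unreadable, so no measured size can be carried over. With both known values at the limit, weak inhibition is the expectation rather than a shift beyond the scatter. Compound 3 is thus estimated at 50000 nM, with a range from 10000 nM to 200000 nM. The implied step, a number no higher from compound 2 to compound 3 (the limit leaves the size open), is itself only an expectation.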

Compound 3, half-maximal inhibitory concentration: > 50000 nM
Compound 3: a limit, no number; the forecaster's own chance of this, stated with the estimate: 65%; the middle value sits exactly at the limit.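

In this assay compound 3 gives > 50000 nM, a limit and not a number. Among the compounds shown here, no step among compound 1, compound 2 and compound 3 can therefore be read: the limit of > 50000 nM in this assay, at which 3 of the 3 values shown sit. The compounds shown leave open whether chloro, bromo and acetyl on this aromatic carbon differ at all in this assay.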